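A Furan-to-Thiophene Swap Within a Small Set

This account rests on a few compounds, and the source may have more. Where it says the series, first, only, none or still open, it means among the compounds named here.

Of the compounds shown here, three sharing one core have been tested in an assay on isolated protein for inhibition of Amine oxidase [flavin-containing] A (Homo sapiens), read by fluorescence; a higher number here means a weaker inhibitor, a lower number a stronger inhibitor. Compound 1, `O=C(/C=C/c1ccoc1)c1cc(O)c(O)c([N+](=O)[O-])c1`, gives 52900 nM in this assay. Compound 3, `N#Cc1ccc(/C=C/C(=O)c2cc(O)c(O)c([N+](=O)[O-])c2)cc1`, gives 45300 nM. Compound 2, `CC(=O)N1N=C(c2cc(O)c(O)c([N+](=O)[O-])c2)CC1c1ccco1`, gives 98000 nM, the highest of the three numbers; its gap to compound 1 is within the usual scatter of this assay, while its gap to compound 3 lies beyond it, so compound 2 can be called the weaker inhibitor only next to compound 3.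

Compound 4, `CC(=O)N1N=C(c2cc(O)c(O)c([N+](=O)[O-])c2)CC1c1cccs1`, differs from compound 2 in a single place: thiophen-2-yl in place of furan-2-yl on a saturated ring carbon. One five-membered aromatic ring with one hetero atom gives way to another of the same size and the same count of donors and acceptors. Going by the values given here, each of the three measured compounds differs from the others in more than one place, so no measured pair isolates this swap, and the data give no direct guide to its effect. The expected step is therefore a 1.2-fold lower number from compound 2 to compound 4 (0.09 log units; within the scatter), a change that is not expected to reach beyond the scatter. Compound 4 is estimated to give about 80000 nM in this assay, with a likely range from 30000 nM to 200000 nM.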

Compound 4, half-maximal inhibitory concentration: 86300 nM
Beside the measured number, compound 4's estimate is 1.1-fold (0.03 log units) below it; low and high end bracket the measured number.
By their numbers in this assay, from the lowest: compounds 3, 1, 4 and 2 (each within the scatter of the next, the first and the last beyond it).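

In this assay, going by these compounds alone, this pair gives the first direct reading of what happens at the saturated ring carbon, with thiophen-2-yl in place of furan-2-yl: a 1.1-fold lower number from compound 2 to compound 4 (0.06 log units; within the scatter). Compound 2 and compound 4 therefore cannot be told apart in this assay, so at this position, on this core, the oxygen of the five-membered aromatic ring can be exchanged for sulfur with no measurable consequence for inhibition. No measurement is available that would explain this result.

The two rings compared have the same size and the same counts of hydrogen-bond donors and acceptors, so the compounds shown leave open whether a group of a different kind on this saturated ring carbon, such as a longer alkyl chain or a primary amine, would give a step beyond the scatter. They also leave open what would follow if the acetyl group on the neighbouring ring atom gave way to another group, such as a carboxylic acid.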